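The source may hold more compounds than are shown below. What is called first, only, known or untested is meant among the compounds shown, and "the series" means these compounds.

Measured so far:
compound 1 `COc1cc2ncnc(Nc3ccc(C#N)cc3F)c2cc1OCCCN1CCNCCNCCNCC1` — > 50000 nM
compound 2 `CCc1cc(Br)ccc1Nc1ncnc2cc(OC)c(OCCCN3CCNCCNCCNCC3)cc12` — > 50000 nM
compound 3 `COc1cc2ncnc(Nc3ccc(C#N)cc3F)c2cc1OCCCN1CCNCCNCC1` — > 50000 nM

The three measured compounds were all tested in a functional assay on A549 cells (Homo sapiens) for antiproliferative activity, read by MTT assay, with a stated time of 72 h; a lower number here means a stronger inhibitor, a higher number a weaker inhibitor. In this assay compound 1 gives > 50000 nM, which is a limit of the assay and not a number. In this assay compound 2 likewise gives > 50000 nM, again a limit. In this assay compound 3 gives > 50000 nM, also a limit.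

The change from compound 1 to compound 2 is 4-bromo-2-ethylphenyl in place of 4-cyano-2-fluorophenyl on a nitrogen on an aromatic ring, and its step in this assay is a step that the two limits leave unreadable from compound 1 to compound 2. The two cores differ by a group of 9 heavy atoms (6 carbon, 3 nitrogen; one nine-membered non-aromatic ring with 3 hetero atoms) in place of a group of 12 heavy atoms (8 carbon, 4 nitrogen; one twelve-membered non-aromatic ring with 4 hetero atoms), on a saturated chain carbon, three bonds along the chain from an oxygen on an aromatic ring, with the step that the two limits leave unreadable from compound 1 to compound 3. Nothing more can be read from these pairs, because of the limit of > 50000 nM in this assay, at which 3 of the 3 values shown sit.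

Compound 4 `CCc1cc(Br)ccc1Nc1ncnc2cc(OC)c(OCCCN3CCNCCNCC3)cc12` has not yet been measured. It differs from compound 3 by 4-bromo-2-ethylphenyl in place of 4-cyano-2-fluorophenyl on a nitrogen on an aromatic ring, and since the place is described in the same words as for the change from compound 1 to compound 2, this is the same change made on the core of compound 3. That earlier change left both partners at the limit, so for compound 4 the step that the limit leaves unreadable from compound 3 to compound 4 is expected to be unreadable as well, resting on compound 3 sitting at > 50000 nM and on compound 2 sitting at > 50000 nM. Compound 4 is therefore estimated at 80000 nM, most likely reported only as a limit, within 30000 nM to 300000 nM.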

Compound 4, half-maximal inhibitory concentration: > 50000 nM
Compound 4 gave a limit, no number; the forecaster's own chance of this, stated with the estimate: 90%; the middle value lies beyond the limit too.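

Compound 4 gives > 50000 nM in this assay, which is a limit of the assay and not a number. No new step can be read for compound 4 against compound 3 or compound 2, because all the values share one limit: the limit of > 50000 nM in this assay, at which 4 of the 4 values shown sit.

The compounds shown leave open whether swapping 4-cyano-2-fluorophenyl for 4-bromo-2-ethylphenyl, or the non-aromatic ring of compound 2 for that of compound 4, changes antiproliferative activity at all.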